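The compounds below may be only part of what the source reports. "The series", "measured", "known", "first", "only" and "open" are said of these compounds alone.

Working notes on the series.

Compound 1 `O=C(NCCCCc1ccccc1)c1cccc(C2SCC(=O)N2c2ccccn2)c1` gives 644 mL.min-1.g-1 in an ADME assay on microsomes from liver (Mus musculus) for metabolic stability, read by LC-MS, using NADPH, with a stated time of 10 min, tested at 0.1 uM; on this read-out higher numbers stand for fast clearance and lower numbers for slow clearance. Compound 2 `COc1ccccc1N1C(=O)CSC1c1cc(F)cc(C(=O)NCCCCc2ccccc2)c1` gives 1430 mL.min-1.g-1 in this assay. Going by the values given here, on these two numbers compound 1 stands lowest, with compound 2 the nearer and only other point, its higher number lying beyond the scatter; no step between them is counted here, so nothing is said of what drives that gap.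

Compound 3 `CC(F)(F)c1cccc(N2C(=O)CSC2c2cccc(C(=O)NCCCCc3ccccc3)c2)c1` has not yet been measured in this assay. Relative to compound 1 it differs in one place: a group of 10 heavy atoms (8 carbon, 2 fluorine; one six-membered aromatic ring of carbon only) in place of a group of 6 heavy atoms (5 carbon, 1 nitrogen; one six-membered aromatic ring with 1 hetero atom), on an amide-type nitrogen in a ring. No step between measured compounds isolates this kind of change, so the expectation rests on the two numbers shown, both of which stand for fast clearance. A modest step upward is expected, a 1.5-fold higher number from compound 1 to compound 3 (0.17 log units; within the scatter), though a step within the scatter would not surprise. Compound 3 is therefore estimated at 950 mL.min-1.g-1, with a range from 400 mL.min-1.g-1 to 2200 mL.min-1.g-1.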

Compound 3, intrinsic clearance in microsomes: 2010 mL.min-1.g-1
The estimate for compound 3 lay 2.1-fold (0.33 log units) below the measured number; the measured number falls inside the stated range.
By their numbers in this assay, from the lowest: compound 1; then compounds 2 and 3 (each within the scatter of the next).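

Going by these compounds alone, on the amide-type nitrogen in a ring, pyridin-2-yl giving way to the group of 10 heavy atoms (8 carbon, 2 fluorine; one six-membered aromatic ring of carbon only) gives a 3.1-fold higher number from compound 1 to compound 3 (0.49 log units; beyond the scatter) in this assay, the first step that isolates a single place. The number at this position therefore responds to the group carried there, and the move is towards faster clearance. The step joins the loss of the ring nitrogen and the arrival of the fluorine-bearing group in one change, and nothing measured here bears on why the number rises.

A plain phenyl on the same nitrogen would separate those two parts of the change. Going by these compounds, whether any group there, such as an amine or a carboxylic acid on the aromatic ring, gives a lower number than compound 1 remains open.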